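Fluoro for formyl on the sulfonyl arm of compound 2

The compounds below may be only part of what the source reports. "The series", "measured", "known", "first", "only" and "open" are said of these compounds alone.

Compound 2 `COc1ccc(-c2cc(=O)c3c(OC)cc(OC)cc3n2S(=O)(=O)c2ccc(C=O)cc2)cc1` is one of two measured members of this small series; the other is compound 1 `COc1ccc(-c2cc(=O)c3c(OC)cc(OC)cc3n2Cc2ccccc2)cc1`. In a functional assay on SUP-B15 cells (Homo sapiens) for antiproliferative activity, with a stated time of 72 h (on this read-out lower numbers stand for an effect already at smaller amounts and higher numbers for an effect only at larger amounts of compound), compound 1 gives only a limit, > 34400 nM. In this assay compound 2 likewise gives only a limit, > 34400 nM. For the measured compounds named here, the single measured step, a step that the two limits leave unreadable from compound 1 to compound 2, is therefore unreadable, both of its ends resting at the limit of > 34400 nM in this assay, at which 2 of the 2 values shown sit. Compound 3 `COc1ccc(-c2cc(=O)c3c(OC)cc(OC)cc3n2S(=O)(=O)c2ccc(F)cc2)cc1` differs from compound 2 by fluoro in place of formyl on an aromatic carbon. Going by the values given here, no measured step bears on a change of this kind, and the one step recorded yields no size at all, so nothing in the numbers points to compound 3 leaving the limit at which compound 2 sits. The step from compound 2 to compound 3 in this assay is expected to be a step that the limit leaves unreadable from compound 2 to compound 3, that is, none beyond the scatter. Compound 3 is accordingly expected at 50000 nM, within 20000 nM to 150000 nM, and most likely reported again only as a limit.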

Compound 3, half-maximal effective concentration: > 65500 nM
Compound 3 ended at the assay's limit; the forecaster's own chance of this, stated with the estimate: 85%; middle value at least 1.3-fold (0.11 log units) from the limit.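

In this assay, for the compounds shown here, compound 3 gives only a limit, > 65500 nM, so no step to compound 3 from compound 1 or compound 2 can be read. The compounds shown leave open whether any group on the shared core gives a measurable antiproliferative effect.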